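Adding a Phenyl to the Chain of Compound 2

The compounds below may be only part of what the source reports. "The series", "measured", "known", "first", "only" and "open" are said of these compounds alone.

Measured in a functional assay on HepG2 cells (Homo sapiens) for cytotoxicity, read by MTT assay, with a stated time of 48 h; a higher number here means a weaker inhibitor, a lower number a stronger inhibitor
- Compound 1 (`CC1=NN(C(=O)CCc2ccccc2)C(c2cc(Br)ccc2O)C1`) gives 17900 nM
- Compound 2 (`CCC(=O)N1N=C(C)CC1c1cc(Br)cc(Br)c1O`) gives 41400 nM

Compound 2 holds the higher of the two numbers, and its gap to compound 1 lies beyond the scatter. Compound 3 (`CC1=NN(C(=O)CCc2ccccc2)C(c2cc(Br)cc(Br)c2O)C1`) departs from compound 2 by phenyl in place of hydrogen on a saturated chain carbon, two bonds along the chain from a carbonyl carbon, with phenyl in place of hydrogen on a saturated chain carbon, two bonds along the chain from a carbonyl carbon. Among the compounds with values here, no measured pair isolates this change. Compound 1 also carries a phenethyl chain and gives 17900 nM, so a moderate move to a lower number in this assay is expected, probably just beyond the scatter. The expected step is a 2.6-fold lower number from compound 2 to compound 3 (0.41 log units; beyond the scatter). The estimated value for compound 3 is 16000 nM, with an expected range of 6000 nM to 42000 nM.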

Compound 3, half-maximal inhibitory concentration: 9170 nM
The estimate for compound 3 lay 1.7-fold (0.24 log units) above the measured number; the range from low to high includes it.
By their numbers in this assay, from the lowest: compounds 3 and 1 (each within the scatter of the next); then compound 2.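

In this assay, within the data shown here, phenyl in place of hydrogen on a saturated chain carbon, two bonds along the chain from a carbonyl carbon, gives a 4.5-fold lower number from compound 2 to compound 3 (0.65 log units; beyond the scatter) and is now read on its own for the first time. Bromo in place of hydrogen on an aromatic carbon, with the phenethyl chain present, gives a 2.0-fold lower number from compound 1 to compound 3 (0.29 log units; within the scatter) and so does not separate these two compounds. Nothing available explains either step.
From the compounds shown here alone, whether a longer chain or an amine at this position would give a similar number remains open.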